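Cytotoxicity on the shared core: amide-side variations at the limit

The source may report more compounds than this note shows. Statements on the series, on what has been measured and on what is new or still open speak of the compounds shown alone.

Measured compounds:
Compound 1 `Cc1cc(CNC(=O)c2cc3nc(C)c([C@H](OC(C)(C)C)C(=O)O)c(-c4cc(F)c5c(c4C)CCCO5)n3n2)ccc1F` in an ADME assay on MT2 cells (Homo sapiens) for cytotoxicity (on this read-out higher numbers stand for lower toxicity in this test and lower numbers for higher toxicity in this test), gives > 40000 nM, which is a limit of the assay and not a number.
Compound 2 `Cc1nc2cc(C(=O)NCc3ccc(F)cc3S(C)(=O)=O)nn2c(-c2cc(F)c3c(c2C)CCCO3)c1[C@H](OC(C)(C)C)C(=O)O` in this assay gives > 40000 nM, again a limit of the assay.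
Compound 3 `Cc1nc2cc(C(=O)NCc3ccc(F)cc3-n3cncn3)nn2c(-c2cc(F)c3c(c2C)CCCO3)c1[C@H](OC(C)(C)C)C(=O)O` in this assay gives > 40000 nM, also a limit of the assay.

Compound 3 therefore stands only at a limit, and the two other values shown sit at the same limit (the limit of > 40000 nM in this assay, at which 3 of the 3 values shown sit). The steps a step that the two limits leave unreadable from compound 1 to compound 2, a step that the two limits leave unreadable from compound 1 to compound 3 and a step that the two limits leave unreadable from compound 2 to compound 3 are all unreadable in size for this reason.

Compound 4 `Cc1nc2cc(C(=O)NCCC(C)C)nn2c(-c2cc(F)c3c(c2C)CCCO3)c1[C@H](OC(C)(C)C)C(=O)O` differs from compound 3 by isobutyl in place of 4-fluoro-2-(1H-1,2,4-triazol-1-yl)phenyl on a saturated chain carbon bound to an amide-type nitrogen. The three measured steps bear on the same position or on the aromatic group at that position, yet none of them gives a readable size, so no direction can be taken from them. Because every value shown sits at the limit of > 40000 nM in this assay, at which 3 of the 3 values shown sit, the expectation for compound 4 is that it too will be reported at the limit, and the step of a number no higher from compound 3 to compound 4 (the limit leaves the size open) is estimated as none beyond the scatter. Compound 4 in this assay is estimated at 40000 nM, with a range from 20000 nM to 80000 nM.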

Compound 4, half-maximal cytotoxic concentration: > 40000 nM
Compound 4: a limit, no number; the forecaster's own chance of this, stated with the estimate: 80%; the middle value sits exactly at the limit.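

Compound 4 joins compound 1, compound 2 and compound 3 at a limit of the assay, so no step among these four can be read in this assay: the limit of > 40000 nM in this assay, at which 4 of the 4 values shown sit.

The compounds shown leave open whether any of these amide-side groups changes the half-maximal cytotoxic concentration on the shared core, and by how much.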